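This account rests on a few compounds, and the source may have more. Where it says the series, first, only, none or still open, it means among the compounds named here.

Within the data shown here, compound 2 `Cc1[nH]n(-c2nc3ccccc3[nH]2)c(=O)c1Cc1cccc(Cl)c1` gives 540 nM in an assay on isolated protein for inhibition of alpha-ketoglutarate-dependent dioxygenase alkB homolog 3 (Homo sapiens), read by polymerase chain reaction, with a stated time of 1 h (a lower number here means a stronger inhibitor, a higher number a weaker inhibitor), and the only companion is compound 1 `COc1ccc(Cc2c(C)[nH]n(-c3nc4ccccc4[nH]3)c2=O)cc1` with 630 nM; the two sit within the scatter of each other. Among the measured compounds shown here, the one measured step, a 1.2-fold lower number from compound 1 to compound 2 (0.07 log units; within the scatter), was therefore flat. Compound 3 `Cc1[nH]n(-c2nc3ccccc3[nH]2)c(=O)c1Cc1ccc(Cl)cc1Cl` carries 2,4-dichlorophenyl in place of 3-chlorophenyl on a saturated chain carbon bound to an aromatic carbon. That step bears only on the swap of one aryl group for another at the same place, so he expects little beyond the scatter, perhaps a slight drop, a 1.2-fold lower number from compound 2 to compound 3 (0.08 log units; within the scatter). For compound 3 he estimates 450 nM in this assay, with a range from 200 nM to 1100 nM.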

Compound 3, half-maximal inhibitory concentration: > 10000 nM
Compound 3 ended at the assay's limit; the forecaster's own chance of this, stated with the estimate: 5%; at least 22-fold (1.34 log units) between middle value and limit.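

Among these compounds, until this result, the aryl group on this saturated chain carbon had seemed open to change, but in this assay the 2,4-dichlorophenyl group gives an at least 18-fold higher number from compound 2 to compound 3 (1.26 log units; beyond the scatter) and an at least 15-fold higher number from compound 1 to compound 3 (1.20 log units; beyond the scatter). The position is therefore not indifferent to its aryl group, and the change from 3-chlorophenyl to 2,4-dichlorophenyl is enough to show this. The reading for compound 3 is a limit of the assay, not a number: the limit of > 10000 nM in this assay, at which 1 of the 3 values shown sits.

On these data alone, whether the loss follows from the added chlorine or from the whole chlorine pattern stays open. So does how a methyl group, a fluorine or an amine on that phenyl ring would fare.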